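Swapping Methoxy for Chloro on a Pendant Phenyl Ring

The source may hold more compounds than are shown below. What is called first, only, known or untested is meant among the compounds shown, and "the series" means these compounds.

Of the compounds shown here, three sharing one core have been tested in a functional assay on BJAB cells (Homo sapiens) for antiproliferative activity, with a stated time of 4 days; on this read-out higher numbers stand for an effect only at larger amounts of compound and lower numbers for an effect already at smaller amounts. Compound 1 `Cc1cc(C)cc(-c2c(C)nn(-c3nc(-c4ccc(Cl)c(Cl)c4)c(SC(C)C)s3)c2C(=O)O)c1` gives 2700 nM. Compound 2 `Cc1nn(-c2nc(-c3ccc(Cl)c(Cl)c3)c(SC(C)C)s2)c(C(=O)O)c1-c1cnccn1` gives 14000 nM, and compound 3 `COc1cccc(-c2c(C)nn(-c3nc(-c4ccc(Cl)c(Cl)c4)c(SC(C)C)s3)c2C(=O)O)c1` gives 14000 nM. Among the compounds with values here, compound 3 therefore stands level with compound 2, the two together giving the highest numbers of the three, and its only step beyond the scatter is a 5.2-fold higher number from compound 1 to compound 3 (0.71 log units; beyond the scatter). The step of a 5.2-fold higher number from compound 1 to compound 2 (0.71 log units; beyond the scatter) is of the same size, while no change at the digits printed from compound 2 to compound 3 (within the scatter).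

Compound 4 `Cc1nn(-c2nc(-c3ccc(Cl)c(Cl)c3)c(SC(C)C)s2)c(C(=O)O)c1-c1cccc(Cl)c1` differs from compound 3 in one place: chloro in place of methoxy on an aromatic carbon. Within the data shown here, none of the measured steps exchanges a methoxy for a chloro, so no step bears on it directly; the only guidance is that compound 1, carrying a different group on the same ring, gives 2700 nM, a lower number. A small expected change for compound 4 is a 2.0-fold lower number from compound 3 to compound 4 (0.30 log units; within the scatter), with a wide range around it. Compound 4 is estimated at 7000 nM, between 2000 nM and 25000 nM.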

Compound 4, half-maximal effective concentration: 13600 nM
The estimate for compound 4 lay 1.9-fold (0.29 log units) below the measured number; the measured number falls inside the stated range.
By their numbers in this assay, from the lowest: compound 1; then compounds 4, 2 and 3 (each within the scatter of the next).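

In this assay, chloro in place of methoxy on this aromatic carbon, meta to a large group, gives a 1.0-fold lower number from compound 3 to compound 4 (0.01 log units; within the scatter), so at this position the two groups cannot be told apart. The 3-chlorophenyl group also reads like pyrazin-2-yl, with a 1.0-fold lower number from compound 2 to compound 4 (0.01 log units; within the scatter), whereas a 5.0-fold higher number from compound 1 to compound 4 (0.70 log units; beyond the scatter) sets 3,5-dimethylphenyl apart from it, so among these four compounds only the 3,5-dimethylphenyl group stands out, with the lower number. Nothing available explains why these groups read alike or why the 3,5-dimethylphenyl group differs.

Still open, going by these compounds, is whether a single methyl, as in 3-methylphenyl, would read like compound 1 or like compound 4. Also open, on these data alone, is whether an amine or a hydroxyl on the same carbon would match chloro and methoxy.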